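Trimethoxyphenyl pyrazole chalcones: cytotoxicity at a single concentration

The compounds below may be only part of what the source reports. "The series", "measured", "known", "first", "only" and "open" are said of these compounds alone.

Measured compounds:
compound 1 `COc1cc(-c2cc(/C=C/C(=O)c3ccc(N)cc3)[nH]n2)cc(OC)c1OC`: 94%
compound 2 `COc1ccc(-c2cc(/C=C/C(=O)c3ccc(N)cc3)[nH]n2)cc1OC`: 93%
compound 3 `COc1cc(C(=O)/C=C/c2cc(-c3cc(OC)c(OC)c(OC)c3)n[nH]2)cc(OC)c1OC`: 94%

In a functional assay on A549 cells (Homo sapiens) for cytotoxicity, read by sulforhodamine B assay, with a stated time of 48 h, tested at 0.1 uM (a lower number here means a stronger effect, a higher number a weaker effect of the compound at the concentration tested), compound 1 gives 94%. Compound 2 differs from it by hydrogen in place of methoxy on an aromatic carbon; in this assay compound 2 gives 93%, so that a number 1 percentage points lower from compound 1 to compound 2 (within the scatter). Compound 3, in this assay, gives 94%, level with compound 1 at the digits read. The difference between the core of compound 1 and the core of compound 3 is not broken down here.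

Compound 4 `COc1ccc(-c2cc(/C=C/C(=O)c3cc(OC)c(OC)c(OC)c3)[nH]n2)cc1OC` is not yet measured. It differs from compound 3 by hydrogen in place of methoxy on an aromatic carbon, the same change as that from compound 1 to compound 2, at a place described in identical terms. In this assay, going by the values given here, the step is expected to be a number 1 percentage points lower from compound 3 to compound 4 (within the scatter), because the one earlier instance of the change gave a number 1 percentage points lower from compound 1 to compound 2 (within the scatter) and compound 3 sits where compound 1 sits. Compound 4 is therefore estimated at 93% in this assay, with a range of 84% to 100% expected.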

Compound 4, a percentage reported as activity, at one concentration (the size of the read-out at that concentration, not a potency): 98%
Beside the measured number, compound 4's estimate is 5 percentage points below it; the range from low to high includes it.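

In this assay, going by these compounds alone, hydrogen in place of methoxy on an aromatic carbon gives a number 4 percentage points higher from compound 3 to compound 4 (within the scatter), so on this core the change leaves no step that can be told from the scatter. Set beside the earlier instance of the change, the two steps do not differ: the same change on two cores in this assay, a number 1 percentage points lower (within the scatter) from compound 1 to compound 2 and a number 4 percentage points higher (within the scatter) from compound 3 to compound 4, 5 percentage points apart, within the scatter of two such steps. Within the data shown here, this shows that the change carried from the core of compound 1 to the core of compound 3 without a difference beyond the scatter, but it rests on only two cores and on a read-out at one concentration, so it gives no potency and no rule for other cores.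

Open, going by these compounds, is whether another group on that aromatic carbon, such as hydroxy, fluorine or a longer chain like ethoxy, would give a step beyond the scatter. Also open, on these data alone, is whether the steps seen here would hold at any other concentration in this assay.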